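This account rests on a few compounds, and the source may have more. Where it says the series, first, only, none or still open, it means among the compounds named here.

Three compounds share one core and have been run in an ADME assay on microsomes from liver (Mus musculus, strain NMRI) for metabolic stability, tested at 2.5 uM; a higher number here means faster removal of the compound, a lower number slower removal. Compound 1 `Brc1cccc2c1nnn2Cc1ccccc1` gives 2.3 mL/min/g. Compound 2 `Fc1cccc(Cn2nnc3c(Br)cccc32)c1` gives 1.3 mL/min/g, and compound 3 `Clc1ccc(Cn2nnc3c(Br)cccc32)cc1` gives 2 mL/min/g. Compound 3 therefore stands second highest of the three numbers, within the scatter of both compound 1 and compound 2. Compound 4 `Fc1cc(Cn2nnc3c(Br)cccc32)ccc1Cl` has not yet been measured; it differs from compound 3 by fluoro in place of hydrogen on an aromatic carbon. The step that bears most directly on this change is a 1.8-fold lower number from compound 1 to compound 2 (0.25 log units; within the scatter), which remained within the scatter; the chloro step a 1.2-fold lower number from compound 1 to compound 3 (0.06 log units; within the scatter) was likewise small. The expected step, a 1.3-fold lower number from compound 3 to compound 4 (0.12 log units; within the scatter), is accordingly small, if anything downward. Compound 4 is expected to give about 1.5 mL/min/g, between 0.8 mL/min/g and 3 mL/min/g.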

Compound 4, intrinsic clearance in a liver preparation (reported as CLH), per the amount of preparation that the assay uses: 2.2 mL/min/g
Estimate against measurement, compound 4: 1.5-fold (0.17 log units) below; the measured number falls inside the stated range.
By their numbers in this assay, from the lowest: compounds 2, 3, 4 and 1 (each within the scatter of the next).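

In this assay, fluoro in place of hydrogen ortho to a chloro group gives a 1.1-fold higher number from compound 3 to compound 4 (0.04 log units; within the scatter), and chloro in place of hydrogen gives a 1.7-fold higher number from compound 2 to compound 4 (0.23 log units; within the scatter), so adding the second halogen leaves the number within the scatter on either route. The fluoro change now reads alike on two cores: the same change on two cores in this assay, a 1.8-fold lower number (0.25 log units; within the scatter) from compound 1 to compound 2 and a 1.1-fold higher number (0.04 log units; within the scatter) from compound 3 to compound 4, 1.9-fold (0.29 log units) apart, within the scatter of two such steps The chloro change does too: the same change on two cores in this assay, a 1.2-fold lower number (0.06 log units; within the scatter) from compound 1 to compound 3 and a 1.7-fold higher number (0.23 log units; within the scatter) from compound 2 to compound 4, 1.9-fold (0.29 log units) apart, within the scatter of two such steps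

What the compounds shown leave open is whether an amine or a carboxylic acid at this place would give a step beyond the scatter. They also leave open whether replacing the bromo group on the shared core would do so.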